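Swapping an ester for phenethyl on the hydroxylated side chain

The source may report more compounds than this note shows. Statements on the series, on what has been measured and on what is new or still open speak of the compounds shown alone.

Three members of this series have been run in an ADME assay, in phosphate buffer, at 28 degrees C, at pH 7.0; a lower number here means that the compound disappears faster, a higher number that the compound lasts longer. Compound 1 `Cn1cc([C@@H](O)[C@H]2C(=O)N3C(C(=O)O)=C(C(C)(C)C)O[C@H]23)nn1` gives 6.8 h. Compound 2 `CC(C)(C)C1=C(C(=O)O)N2C(=O)[C@H]([C@H](O)CCc3ccncc3)[C@@H]2O1` gives 7.1 h. Compound 3 `CC(C)(C)OC(=O)[C@H](O)[C@H]1C(=O)N2C(C(=O)O)=C(C(C)(C)C)O[C@H]12` gives 10.7 h, the highest of the three numbers, although both others sit within the usual scatter of it, so the three stand as one undifferentiated group in this assay.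

Compound 4 `CC(C)(C)C1=C(C(=O)O)N2C(=O)[C@H]([C@@H](O)CCc3ccccc3)[C@H]2O1` differs from compound 3 in one place: phenethyl in place of tert-butoxycarbonyl on a saturated chain carbon bound to an oxygen on a saturated carbon and a saturated ring carbon. Going by the values given here, no pair of measured compounds isolates this exact change. The nearest relative of compound 4 in the set is compound 2, which carries a hydroxylated chain with an aromatic ring in place of the ester, and compound 2 gives 7.1 h. On that basis the expected step is a 1.3-fold lower number from compound 3 to compound 4 (0.13 log units; within the scatter), which stays within the scatter, with no direction claimed beyond it. Compound 4 is therefore estimated at 8 h, with a likely range from 4.5 h to 14 h.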

Compound 4, half-life: 39 h
Estimate against measurement, compound 4: 4.9-fold (0.69 log units) below; the measured number lies above the stated range.
By their numbers in this assay, from the lowest: compounds 1, 2 and 3 (each within the scatter of the next); then compound 4.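

In this assay phenethyl in place of tert-butoxycarbonyl on a saturated chain carbon bound to an oxygen on a saturated carbon and a saturated ring carbon gives a 3.6-fold higher number from compound 3 to compound 4 (0.56 log units; beyond the scatter) and so provides the first step shown here that lies beyond the scatter. Going by these compounds alone, the earlier compounds did not differ from one another in one place, so only this pair shows that a change at this position can move the half-life. Nothing at hand explains the step.

The change removes the ester and adds the aromatic ring together, so the compounds shown leave open which of the two carries the step. Going by these compounds, whether benzyl, cyclohexylethyl or a plain butyl chain would give a similar number remains open, as does the outcome of placing an amine on the phenyl ring.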